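From hydroxymethyl to ethoxycarbonyl: estimating compound 4

The source may report more compounds than this note shows. Statements on the series, on what has been measured and on what is new or still open speak of the compounds shown alone.

All values come from a functional assay on HeLa cells (Homo sapiens) for cytotoxicity, read by MTT assay, with a stated time of 48 h (on this read-out higher numbers stand for weaker inhibition and lower numbers for stronger inhibition), and are shown here
Compound 1 `COc1cc([C@@H]2C[C@]2(CO)C(=O)Nc2ccccc2Cl)cc(OC)c1OC` gives 8100 nM
Compound 2 `COc1cc([C@@H]2C[C@]2(CO)C(=O)NCc2ccc(C)cc2)cc(OC)c1OC` gives 17400 nM
Compound 3 `CCOC(=O)[C@]1(C(=O)Nc2ccccc2)C[C@@H]1c1cc(OC)c(OC)c(OC)c1` gives > 100000 nM (a limit, not a number)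

Of the two actual numbers, compound 2 has the higher (17400 nM). Compared with compound 2, compound 4 (`CCOC(=O)[C@]1(C(=O)NCc2ccc(C)cc2)C[C@H]1c1cc(OC)c(OC)c(OC)c1`) has ethoxycarbonyl in place of hydroxymethyl on a saturated ring carbon. Among the measured compounds shown here, the only measured step (a 2.1-fold higher number from compound 1 to compound 2 (0.33 log units; beyond the scatter)) was modest and changed a different place, so it does not size this change. Compound 3, which also carries ethoxycarbonyl, gives only a limit (> 100000 nM). On the strength of compound 3 at the limit of > 100000 nM in this assay, at which 1 of the 3 values shown sits, a clearly higher number is expected in this assay. The expected step is a 3.4-fold higher number from compound 2 to compound 4 (0.54 log units; beyond the scatter) and it is only an estimate. For compound 4 the estimated value is 60000 nM with an expected range from 20000 nM to 180000 nM.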

Compound 4, half-maximal inhibitory concentration: 28500 nM
For compound 4 the middle estimate is 2.1-fold (0.32 log units) above the measured one, and the stated range covers the measured number.
By their numbers in this assay, from the lowest: compound 1; then compounds 2 and 4 (each within the scatter of the next). At a limit, above all of these: compound 3.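

At this position on the saturated ring carbon, the step of a 1.6-fold higher number from compound 2 to compound 4 (0.21 log units; within the scatter) shows that ethoxycarbonyl and hydroxymethyl cannot be told apart in this assay when the amide carries 4-methylbenzyl. With that amide, the hydrogen-bond donor of hydroxymethyl is therefore not needed to keep this level of cytotoxicity. Compound 3, which also carries ethoxycarbonyl but has a different amide group, gives only a limit, not a number: the limit of > 100000 nM in this assay, at which 1 of the 4 values shown sits.

Going by these compounds, whether a carboxylic acid or an aminomethyl group at this position would read the same remains open. So does whether ethoxycarbonyl would match hydroxymethyl with the 2-chlorophenyl amide of compound 1.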